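A few compounds are considered here, and "the series" means these few. Any claim that something is new, unique, unknown or untested is made for them only; others in the source may bear on it.

Measured compounds in an assay on cells for inhibition of Nicotinamide N-methyltransferase (Homo sapiens), with stated times of 10 min and 30 min; a lower number here means a stronger inhibitor, a higher number a weaker inhibitor:
compound 1 `NC(=O)CCCN(Cc1ccc2ccccc2c1)C[C@H]1O[C@@H](n2cnc3c(N)ncnc32)[C@H](O)[C@@H]1O`, 112000 nM
compound 2 `Nc1ncnc2c1ncn2[C@@H]1O[C@H](CN(CCCC(=O)O)Cc2ccc3ccccc3c2)[C@@H](O)[C@H]1O`, > 250000 nM, a limit of the assay
compound 3 `Nc1ncnc2c1ncn2[C@@H]1O[C@H](CN(CCCCC(=O)O)Cc2ccc3ccccc3c2)[C@@H](O)[C@H]1O`, > 250000 nM, a limit of the assay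

Compound 3 thus stands at the upper limit of this assay, where two of the three values sit (the limit of > 250000 nM in this assay, at which 2 of the 3 values shown sit). Compound 4 `Nc1ncnc2c1ncn2[C@@H]1O[C@H](CN(CCC[C@H](N)C(=O)O)Cc2ccc3ccccc3c2)[C@@H](O)[C@H]1O` differs from compound 3 by amino in place of hydrogen on a saturated chain carbon bound to a carbonyl carbon and a saturated chain carbon. Among the compounds with values here, the steps that bear on it are an at least 2.2-fold higher number from compound 1 to compound 3 (0.34 log units; beyond the scatter), and a step that the two limits leave unreadable from compound 2 to compound 3; both end at a limit, so no measured step tells how an amino on that chain carbon shifts the number. Compound 4 is therefore expected to stay near the limit, with a step of an at least 1.2-fold lower number from compound 3 to compound 4 (0.09 log units; that floor lies within the scatter) that cannot be read with confidence. The estimate for compound 4 in this assay is 200000 nM, ranging from 50000 nM to 500000 nM.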

Compound 4, half-maximal inhibitory concentration: > 250000 nM
Compound 4: only a limit was reported (the forecaster's own chance of this, stated with the estimate: 60%); at least 1.2-fold (0.09 log units) between middle value and limit.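

In this assay the amino on the saturated chain carbon leaves compound 4 at a limit of the assay, > 250000 nM, so adding it to the carboxylic acid chain brings back no readable value. Within the data shown here, the one readable step is an at least 2.2-fold higher number from compound 1 to compound 4 (0.34 log units; beyond the scatter), while the steps to compound 4 from compound 2 and compound 3 cannot be read, since both ends are limits. The limit now holds most of the compounds shown: the limit of > 250000 nM in this assay, at which 3 of the 4 values shown sit.

As far as these compounds go, how far the amino shifts the number beyond that limit stays open. So does how an amino on the carbamoyl chain of compound 1, or a longer chain ending in carbamoyl, would read.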